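The source may report more compounds than this note shows. Statements on the series, on what has been measured and on what is new or still open speak of the compounds shown alone.

Compound 1 `Cc1ccc(NC(=S)NC(=O)c2cn(-c3ccccc3)nc2-c2ccc(Cl)cc2)cc1` serves as the reference point of this set. In a functional assay on A549 cells (Homo sapiens) for inhibition, read by CCK-8 assay, with a stated time of 48 h (a higher number here means a weaker inhibitor, a lower number a stronger inhibitor), compound 1 gives 2690 nM. Two relatives have been measured alongside it: compound 2 `Cc1ccc(-c2nn(-c3ccccc3)cc2C(=O)NC(=S)Nc2ccc(Cl)cc2)cc1` gives 3170 nM, and compound 3 `O=C(NC(=S)Nc1ccc(F)cc1)c1cn(-c2ccccc2)nc1-c1ccc(Cl)cc1` gives 3980 nM. Among the compounds with values here, compound 1 has the lowest of the three numbers, yet the spread is narrow: the single one-point step among them, a 1.5-fold higher number from compound 1 to compound 3 (0.17 log units; within the scatter), lies within the scatter, and the values of compound 1 and compound 2 are likewise within the scatter of each other, so none of the three can be set apart from the rest.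

Compound 4 `COc1ccc(-c2nn(-c3ccccc3)cc2C(=O)NC(=S)Nc2ccc(C)cc2)cc1` differs from compound 1 by methoxy in place of chloro on an aromatic carbon. Within the data shown here, no measured step touches this change: the only step on record exchanges methyl for fluoro elsewhere in the molecule, and even that stayed within the scatter. Nothing here tells how a methoxy compares with a chloro at this place, so the expectation is no step beyond the scatter. The estimated step is a 1.1-fold higher number from compound 1 to compound 4 (0.05 log units; within the scatter), which stays within the scatter. Compound 4 is expected to give about 3000 nM, with a range from 1200 nM to 7500 nM.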

Compound 4, half-maximal inhibitory concentration: 1250 nM
Compound 4: middle estimate off by 2.4-fold (0.38 log units), on the high side; the range from low to high includes it.
By their numbers in this assay, from the lowest: compound 4; then compounds 1, 2 and 3 (each within the scatter of the next).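

The step of a 2.2-fold lower number from compound 1 to compound 4 (0.33 log units; beyond the scatter) is the only one in this assay that goes beyond the scatter, though it is modest. It shows that this place, on an aromatic carbon para to a large group, is not indifferent to what stands there, whereas the exchange of methyl for fluoro elsewhere in the molecule, a 1.5-fold higher number from compound 1 to compound 3 (0.17 log units; within the scatter), stayed within the scatter. No evidence at hand bears on what lies behind this lower number.

The compounds shown leave open whether the gain is particular to methoxy or would also appear with a hydroxyl, an amine or a longer chain such as ethoxy at this place. With a single step on record here, they also leave open whether the same exchange would give a similar step with fluoro in place of the methyl elsewhere in the molecule.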